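The compounds below may be only part of what the source reports. "The series", "measured", "known", "first", "only" and "open" are said of these compounds alone.

Of the compounds shown here, three built on one shared core have so far been measured in a functional assay on HEK293 cells for antagonist activity at transient receptor potential cation channel subfamily V member 1 (Homo sapiens), read by calcium flux; a higher number here means a weaker inhibitor, a lower number a stronger inhibitor. Compound 1 `FC(F)(F)c1ccc(Nc2nc(N3CCC3)nc3sc(Nc4c(Cl)cccc4Cl)nc23)cc1` gives 59 nM, compound 2 `FC(F)(F)c1ccc(Nc2nc(N3CCCC3)nc3sc(Nc4c(Cl)cccc4Cl)nc23)cc1` gives 12 nM, and compound 3 `FC(F)(F)c1ccc(Nc2nc(N3CCNCC3)nc3sc(Nc4c(Cl)cccc4Cl)nc23)cc1` gives 5000 nM. Compound 3 therefore stands highest of the three, with compound 1 the nearest to it and compound 2 the furthest. Both steps that lead to compound 3 are large: an 85-fold higher number from compound 1 to compound 3 (1.93 log units; beyond the scatter) and a 420-fold higher number from compound 2 to compound 3 (2.62 log units; beyond the scatter). The step among the two ring amines without a hydrogen-bond donor is more modest: a 4.9-fold lower number from compound 1 to compound 2 (0.69 log units; beyond the scatter).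

Compound 4 `CN(C)c1nc(Nc2ccc(C(F)(F)F)cc2)c2nc(Nc3c(Cl)cccc3Cl)sc2n1` has not yet been measured. It differs from compound 3 in one place: dimethylamino in place of piperazin-1-yl on an aromatic carbon. The entering group, like the azetidin-1-yl of compound 1 and the pyrrolidin-1-yl of compound 2, carries 0 hydrogen-bond donors, whereas the piperazin-1-yl that leaves carries 1, and the large rises in both steps toward compound 3 accompanied the arrival of that group. Going by the values given here, no measured compound carries an acyclic amine at this position, so the size of the return is uncertain. Because of an 85-fold higher number from compound 1 to compound 3 (1.93 log units; beyond the scatter) a large fall in this assay is expected for compound 4, namely a 130-fold lower number from compound 3 to compound 4 (2.10 log units; beyond the scatter). Compound 4 is estimated at 40 nM in this assay, within a range from 8 nM to 250 nM.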

Compound 4, half-maximal inhibitory concentration: 59 nM
Compound 4: the middle estimate sits 1.5-fold (0.17 log units) below what was measured; measured number inside the range.
By their numbers in this assay, from the lowest: compound 2; then compounds 1 and 4 (each within the scatter of the next); then compound 3.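

Compound 4 shows that this carbon does not need a ring amine for a low number in this assay: dimethylamino, with no ring, gives an 85-fold lower number from compound 3 to compound 4 (1.93 log units; beyond the scatter) when it replaces piperazin-1-yl, so the high number of compound 3 is not shared by this smaller acyclic group with 0 hydrogen-bond donors. Among the groups with 0 hydrogen-bond donors, azetidin-1-yl and dimethylamino cannot be told apart, with no change at the digits printed from compound 1 to compound 4 (within the scatter), while pyrrolidin-1-yl stays distinct, with a 4.9-fold higher number from compound 2 to compound 4 (0.69 log units; beyond the scatter) in the change to dimethylamino. Across the four compounds, therefore, compound 3 alone carries a hydrogen-bond donor at this position and alone has the highest number of the set, and compound 2 is the strongest inhibitor of the set, though four compounds are a narrow base for that pattern. No measured evidence at hand explains these differences.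

Piperazin-1-yl differs from the other three groups in its size, its ring atoms and its donor count together, so the compounds shown do not say which of these goes with its high number. On these data alone, how morpholin-4-yl, piperidin-1-yl, 4-methylpiperazin-1-yl or a longer chain such as diethylamino would read at this carbon remains open.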